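Swapping fluoro for trifluoromethoxy on the aryl piperazine ring

The source may report more compounds than this note shows. Statements on the series, on what has been measured and on what is new or still open speak of the compounds shown alone.

Compound 2 `NC(=O)OC(CCN1CCN(c2ccc(F)cc2)CC1)c1ccccc1`: 88%
Compound 1 `NC(=O)OC(CCN1CCN(c2ccc(F)cc2)CC1)c1ccc(F)cc1`: 52%

In a functional assay on the whole organism for inhibition, with Mus musculus as the target, in the writhing test, with a stated time of 1 h, at a dose of 10 mg/kg by the oral route (on this read-out higher numbers stand for more inhibition at the one dose given (going by the name of the read-out) and lower numbers for less inhibition), compound 2 gives 88%, the higher of the two numbers measured. Compound 1 gives 52%, and the step of a number 36 percentage points higher from compound 1 to compound 2 (beyond the scatter) is the only one known, a large one. Compound 3 `NC(=O)OC(CCN1CCN(c2ccc(OC(F)(F)F)cc2)CC1)c1ccccc1` differs from compound 2 by trifluoromethoxy in place of fluoro on an aromatic carbon. That single known step concerns the other aromatic ring, so nothing measured bears directly on this change. A modest drop, a number 18 percentage points lower from compound 2 to compound 3 (beyond the scatter), is expected, with a wide range of uncertainty. Compound 3 is therefore estimated at 70%, from 40% to 95%.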

Compound 3, a percentage reported as inhibition, in the whole organism at one dose (the size of the read-out at that dose, not a potency): 18%
Compound 3: the middle estimate sits 52 percentage points above what was measured, outside the stated range (below it).
By their numbers in this assay, from the lowest: compound 3; then compound 1; then compound 2.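

In this assay, the group on this aromatic carbon, para to a large group, matters a great deal: trifluoromethoxy in place of fluoro gives a number 70 percentage points lower from compound 2 to compound 3 (beyond the scatter). So the other aromatic ring is not the only place where one change moves this read-out strongly. Nothing available here explains the loss. The compounds shown leave open whether a trifluoromethyl or a methoxy group at this place would keep the inhibition of compound 2 or lose it as well.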